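The source may report more compounds than this note shows. Statements on the series, on what has been measured and on what is new or still open speak of the compounds shown alone.

Of the compounds shown here, two sharing one core have been measured. In an assay for inhibition of ATP-dependent RNA helicase DDX3X (Homo sapiens), read by FRET, with a stated time of 40 min, in the presence of a further agent that is not named here (a lower number here means a stronger inhibitor, a higher number a weaker inhibitor), compound 1 `CCCCc1cn(-c2ccc(NC(=O)Nc3ccccc3C)cc2)nn1` gives 300 nM. Compound 2 `CC(=O)CCc1cn(-c2ccc(NC(=O)Nc3cccc(F)c3)cc2)nn1` gives 2400 nM in this assay, the higher of the two numbers, and its gap to compound 1 lies beyond the scatter. Compound 3 `CCCCc1cn(-c2ccc(NC(=O)Nc3cccc(F)c3)cc2)nn1` differs from compound 2 in one place: ethyl in place of acetyl on a saturated chain carbon, two bonds along the chain from an aromatic carbon. Within the data shown here, compound 3 carries the same butyl chain as compound 1, though the two also differ elsewhere, so no measured step covers this change directly. Compound 1 gives 300 nM, which points towards a lower number. The step is expected to be a 4.0-fold lower number from compound 2 to compound 3 (0.60 log units; beyond the scatter). Compound 3 is therefore estimated at 600 nM, within 200 nM to 2000 nM.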

Compound 3, half-maximal inhibitory concentration: 600 nM
Compound 3: middle estimate and measured number agree at the digits printed; low and high end bracket the measured number.
By their numbers in this assay, from the lowest: compounds 1 and 3 (each within the scatter of the next); then compound 2.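

In this assay, changing the 2-acetylethyl chain to butyl with the rest of the molecule held constant gives a 4.0-fold lower number from compound 2 to compound 3 (0.60 log units; beyond the scatter), so this single change at the chain carbon separates the two compounds clearly. Placing 3-fluorophenyl in place of 2-methylphenyl on the amide-type nitrogen gives a 2.0-fold higher number from compound 1 to compound 3 (0.30 log units; within the scatter), so with the butyl chain in place, these two groups are not told apart. Nothing available explains either step.

On these data alone, whether a longer chain, a hydroxyl or an amine at the chain end would change the number remains open. So does the effect of 2-methylphenyl on a compound carrying the 2-acetylethyl chain.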